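The compounds below may be only part of what the source reports. "The series", "measured", "known", "first", "only" and "open" are said of these compounds alone.

Measured so far in a functional assay on spleen for antagonist activity at Alpha-1B adrenergic receptor (Rattus norvegicus); on this read-out higher numbers stand for higher potency (the scale is a negative logarithm) and lower numbers for lower potency:
compound 1 `COc1cccc(OC)c1OCCNCCOc1ccccc1OCc1cccc(Cl)c1` gives 7.93
compound 2 `COc1cccc(OC)c1OCCNCCOc1ccccc1OCc1cccc([N+](=O)[O-])c1` gives 8.74
compound 3 `COc1ccccc1COc1ccccc1OCCNCCOc1c(OC)cccc1OC` gives 8.13

Compound 1 stands lowest of the three numbers. Its nearest neighbour is compound 3, the step of a number 0.20 log units higher from compound 1 to compound 3 (within the scatter); the furthest is compound 2, the step of a number 0.81 log units higher from compound 1 to compound 2 (beyond the scatter).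

Compound 4 `CCOc1ccc(COc2ccccc2OCCNCCOc2c(OC)cccc2OC)cc1` is the next compound to be measured. Against compound 1 the difference is 4-ethoxyphenyl in place of 3-chlorophenyl on a saturated chain carbon bound to an oxygen on an aromatic ring.

Among the compounds with values here, two measured steps bear on this. The closest parallel is the exchange of the aryl group at the same place, from compound 1 to compound 3, a number 0.20 log units higher from compound 1 to compound 3 (within the scatter). The other exchange at that place, from compound 2 to compound 3, a number 0.61 log units lower from compound 2 to compound 3 (beyond the scatter), shows that the aryl group here can move the number beyond the scatter, but that step starts from the nitro compound, not from compound 1. With only these steps to go on, the replacement of 3-chlorophenyl by another substituted phenyl is expected to leave the number close to that of compound 1, with a step of about a number 0.17 log units higher from compound 1 to compound 4 (within the scatter) in this assay, not clearly beyond the scatter.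

Compound 4 is therefore estimated at 8.1 in this assay, expected to fall between 7.5 and 8.7.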

Compound 4, negative logarithm of the antagonist equilibrium constant: 8.23
For compound 4 the middle estimate is 0.13 log units below the measured one; low and high end bracket the measured number.
By their numbers in this assay, from the lowest: compounds 1, 3 and 4 (each within the scatter of the next); then compound 2.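

At the aryl group on the saturated chain carbon bound to an oxygen on an aromatic ring, 4-ethoxyphenyl reads the same within the scatter as 3-chlorophenyl (a number 0.30 log units higher from compound 1 to compound 4 (within the scatter)) and 2-methoxyphenyl (a number 0.10 log units higher from compound 3 to compound 4 (within the scatter)) in this assay. Three differently substituted phenyl groups now sit together, and 3-nitrophenyl in compound 2 is the one exception, with a gap beyond the scatter to the new compound as well (a number 0.51 log units lower from compound 2 to compound 4 (beyond the scatter)). Nothing available accounts for this separation of compound 2.

Open, on these data alone, is whether a nitrile or a carboxylic acid in place of the nitro group would share the standing of compound 2. Equally open, as far as these compounds go, is how an amine on that phenyl ring, or a longer chain in place of the ethoxy group, would read.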